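A few compounds are considered here, and "the series" means these few. Any claim that something is new, unique, unknown or untested is made for them only; others in the source may bear on it.

Series notes. In an assay on cells for displacement of a labelled ligand from adenosine receptor A1 (Homo sapiens), read by scintillation counting, with a stated time of 120 min, tested at 1 uM (a lower number here means less inhibition, a higher number more inhibition at the concentration tested (going by the name of the read-out)), compound 1 `COc1ccc(C(=O)Nc2nc(-c3ccccc3)cn3cc(-c4ccccc4)nc23)cc1` gives 6%. Compound 2 `O=C(Nc1nc(-c2ccccc2)cn2cc(-c3ccccc3)nc12)c1ccc(Cl)cc1` carries the change chloro in place of methoxy on an aromatic carbon relative to compound 1, and in this assay compound 2 gives 1%; the step of a number 5 percentage points lower from compound 1 to compound 2 (within the scatter) is small. Compound 3 `COc1ccc(-c2cn3cc(-c4ccccc4)nc3c(N)n2)cc1` has a different core; how it differs from compound 1 is not broken down here. In this assay compound 3 gives 20%, the highest of the three numbers. Its gap to compound 1 is beyond the scatter. Its gap to compound 2 is beyond the scatter as well.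

Compound 4 `Nc1nc(-c2ccc(Cl)cc2)cn2cc(-c3ccccc3)nc12` has not been measured in this assay. It stands to compound 3 as compound 2 stands to compound 1: the change chloro in place of methoxy on an aromatic carbon is the same change, at the same place on a six-membered aromatic ring of carbon only, para to a large group. Carried over to the core of compound 3, the step is expected to be a number 5 percentage points lower from compound 3 to compound 4 (within the scatter), resting on the single earlier instance a number 5 percentage points lower from compound 1 to compound 2 (within the scatter), which stayed within the scatter. Compound 4 is therefore expected to give about 15% in this assay, between 3% and 28%.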

Compound 4, a percentage reported as inhibition, at one concentration (the size of the read-out at that concentration, not a potency): 3%
The estimate for compound 4 lay 12 percentage points above the measured number; measured number inside the range.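

In this assay, the change from 4-methoxyphenyl to 4-chlorophenyl on the core of compound 3 reads as a number 17 percentage points lower from compound 3 to compound 4 (beyond the scatter). Although this step is beyond the scatter and the earlier one is not, the two instances cannot be told apart: the same change on two cores in this assay, a number 5 percentage points lower (within the scatter) from compound 1 to compound 2 and a number 17 percentage points lower (beyond the scatter) from compound 3 to compound 4, 12 percentage points apart, within the scatter of two such steps

The pair therefore gives no ground for saying that the core alters the size of this change, and two instances are too few to show that its size carries over unchanged from one core to another. Only methoxy and chloro appear on this aromatic carbon in the compounds shown, so it remains open how a fluoro, a methyl or a dimethylamino group would read on either core. Also open, as far as these compounds go, is how the change would read on a core carrying an acetamide or a longer alkyl amide where compound 3 has its free amine.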